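The compounds below may be only part of what the source reports. "The series", "measured", "known", "first", "only" and "open" are said of these compounds alone.

Measured so far in a functional assay on MCF7 cells (Homo sapiens) for inhibition, with a stated time of 96 h; on this read-out higher numbers stand for weaker inhibition and lower numbers for stronger inhibition:
- compound 1 `COc1cc(C(=O)c2cn(-c3ccc(F)cc3)cc2-c2ccsc2)cc(OC)c1OC`: 15 nM
- compound 2 `COc1cc(C(=O)c2cn(-c3ccc(F)cc3)cc2-c2ncco2)cc(OC)c1OC`: 93 nM
- compound 3 `COc1cc(C(=O)c2cn(-c3ccc(C)cc3)cc2-c2ccncc2)cc(OC)c1OC`: 9 nM

Compound 3, at 9 nM, lies within the scatter of compound 1. Compound 2 stands apart from it, with a higher number that lies beyond the scatter.

Next is compound 4 `COc1cc(C(=O)c2cn(-c3ccc(F)cc3)cc2-c2ccncc2)cc(OC)c1OC`. It differs from compound 3 by one change: fluoro in place of methyl on an aromatic carbon. In words, fluoro takes the place of methyl on an aromatic carbon, turning 4-methylphenyl into 4-fluorophenyl.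

For the measured compounds named here, no measured step covers this change. The only one available is a 6.2-fold higher number from compound 1 to compound 2 (0.79 log units; beyond the scatter), where 1,3-oxazol-2-yl replaces thiophen-3-yl, and that is a different change in a different place. It shows that the series can respond to a single replacement, but it does not give a size for this one.

The indirect evidence is that compound 1 carries 4-fluorophenyl and still gives 15 nM, so that group is compatible with a low number in this assay. Two compounds carrying it are too few to establish a trend, and compound 2, at 93 nM, shows that its presence does not guarantee one.

No shift beyond the scatter is therefore expected. The expected change is a 1.3-fold higher number from compound 3 to compound 4 (0.12 log units; within the scatter). Compound 4 is estimated at 12 nM, with an expected range of 4 nM to 35 nM.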

Compound 4, half-maximal inhibitory concentration: 9 nM
Compound 4: the middle estimate sits 1.3-fold (0.12 log units) above what was measured; low and high end bracket the measured number.
By their numbers in this assay, from the lowest: compounds 3, 4 and 1 (each within the scatter of the next); then compound 2.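

Working notes on the series: in this assay, the first direct reading of the swap from 4-methylphenyl to 4-fluorophenyl, with pyridin-4-yl held fixed, gives no shift (no change at the digits printed from compound 3 to compound 4 (within the scatter)), so fluoro and methyl cannot be told apart at this place on the aromatic ring. For the compounds shown here, with 4-fluorophenyl held fixed, the other variable position now has two comparisons: the change from 1,3-oxazol-2-yl is large (a 10-fold lower number from compound 2 to compound 4 (1.01 log units; beyond the scatter)), whereas the change from thiophen-3-yl stays within the scatter (a 1.7-fold lower number from compound 1 to compound 4 (0.22 log units; within the scatter)), leaving 1,3-oxazol-2-yl as the only one of these three groups that stands apart. Nothing available here accounts for either outcome.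

On these data alone, two small groups at one place cannot show how much the para position tolerates, so it remains open whether a methoxy, an amine or a longer chain there would also leave the number unchanged. As far as these compounds go, it is also open whether the gap seen with 1,3-oxazol-2-yl persists alongside 4-methylphenyl, and whether an amine or a carboxylic acid in place of pyridin-4-yl would keep the number within the scatter of compound 4.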